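A Fluoro Substituent on the 4-Methoxyphenyl Ring

A few compounds are considered here, and "the series" means these few. Any claim that something is new, unique, unknown or untested is made for them only; others in the source may bear on it.

Compound 3 `COc1ccc(C(=O)/C=C/c2cc(-c3cc(OC)c(OC)c(OC)c3)n[nH]2)cc1` gives 810 nM in a functional assay on MCF7 cells (Homo sapiens) for inhibition, read by MTT assay, with a stated time of 48 h (on this read-out higher numbers stand for weaker inhibition and lower numbers for stronger inhibition), the lowest of the three numbers measured. Compound 1 `COc1cc(-c2cc(/C=C/C(=O)c3ccc(N)cc3)[nH]n2)cc(OC)c1OC` gives 1600 nM in this assay, and a 2.0-fold lower number from compound 1 to compound 3 (0.30 log units; within the scatter). Compound 2 `COc1cc(-c2cc(/C=C/C(C)=O)[nH]n2)cc(OC)c1OC` gives 20100 nM; a 25-fold lower number from compound 2 to compound 3 (1.39 log units; beyond the scatter), and a 13-fold higher number from compound 1 to compound 2 (1.10 log units; beyond the scatter). Compound 4 `COc1ccc(C(=O)/C=C/c2cc(-c3cc(OC)c(OC)c(OC)c3)n[nH]2)cc1F` differs from compound 3 by fluoro in place of hydrogen on an aromatic carbon, a single fluorine ortho to a methoxy group and meta to a large group. Going by the values given here, no measured step touches that position: the steps seen concern the group on the carbonyl carbon and the substituent on its aromatic ring, one within the scatter and two large. Lacking any step with a fluoro, the author expects compound 4 to stay within the scatter of compound 3, a 1.0-fold lower number from compound 3 to compound 4 (0.01 log units; within the scatter), and estimates compound 4 at 800 nM, ranging from 300 nM to 2200 nM.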

Compound 4, half-maximal inhibitory concentration: 3000 nM
Compound 4: the middle estimate sits 3.8-fold (0.57 log units) below what was measured, outside the stated range (above it).
By their numbers in this assay, from the lowest: compounds 3, 1 and 4 (each within the scatter of the next, the first and the last beyond it); then compound 2.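

In this assay, going by these compounds alone, this position on the 4-methoxyphenyl ring, untouched by the earlier steps, turns out not to be silent: fluoro in place of hydrogen gives a 3.7-fold higher number from compound 3 to compound 4 (0.57 log units; beyond the scatter) on its own. With the fluoro present, replacing methyl on the carbonyl carbon still helps, with a 6.7-fold lower number from compound 2 to compound 4 (0.83 log units; beyond the scatter) as the step, while a 1.9-fold higher number from compound 1 to compound 4 (0.27 log units; within the scatter) leaves no readable difference from the 4-aminophenyl group. No evidence here accounts for the fluoro step. The compounds shown leave open whether chloro, hydroxy or methyl at this same carbon would give a similar step.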